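This account rests on a few compounds, and the source may have more. Where it says the series, first, only, none or still open, it means among the compounds named here.

Among the compounds with values here, compound 3 `COC(=O)C1=C(C)NC(=O)N(C(=O)NCCCN2CCN(c3ccc(OC)cc3C)CC2)C1c1ccc(F)c(F)c1` gives 510 nM in an assay on liver for binding affinity to Alpha-1B adrenergic receptor (Homo sapiens), using microsomes (a lower number here means a stronger inhibitor, a higher number a weaker inhibitor), the highest of the three numbers measured so far. Compound 1 `COC(=O)C1=C(C)NC(=O)N(C(=O)NCCCN2CCN(c3ccc(Cl)cc3)CC2)C1c1ccc(F)c(F)c1` gives 17 nM and compound 2 `CCOc1ccccc1N1CCN(CCCNC(=O)N2C(=O)NC(C)=C(C(=O)OC)C2c2ccc(F)c(F)c2)CC1` gives 8.8 nM in this assay; the step of a 1.9-fold lower number from compound 1 to compound 2 (0.29 log units; within the scatter) lies within the scatter, so those two are not ordered against each other. Against both of them compound 3 stands well apart: a 30-fold higher number from compound 1 to compound 3 (1.48 log units; beyond the scatter) and a 58-fold higher number from compound 2 to compound 3 (1.76 log units; beyond the scatter), each beyond the scatter, so compound 3 is the weakest of the three.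

Compound 4 `COC(=O)C1=C(C)NC(=O)N(C(=O)NCCCN2CCN(c3cccc([N+](=O)[O-])c3)CC2)C1c1ccc(F)c(F)c1` carries the change (3-nitrophenyl in place of 4-methoxy-2-methylphenyl on an amine nitrogen in a ring). Within the data shown here, no measured step brings in a 3-nitrophenyl, so the only steps that bear on this one are the two that placed the 4-methoxy-2-methylphenyl on that ring nitrogen, a 30-fold higher number from compound 1 to compound 3 (1.48 log units; beyond the scatter) and a 58-fold higher number from compound 2 to compound 3 (1.76 log units; beyond the scatter). Taking that group away is expected to undo most of the loss, because compound 1 at 17 nM and compound 2 at 8.8 nM show that two other aryl groups on the same ring nitrogen both sit low; how closely a 3-nitrophenyl follows them is not shown. A step downward is therefore expected, a 13-fold lower number from compound 3 to compound 4 (1.11 log units; beyond the scatter), with wider uncertainty than a repeat of a measured pair would carry. Compound 4 is estimated at 40 nM, within the range 8 nM to 250 nM.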

Compound 4, inhibition constant: 150 nM
Beside the measured number, compound 4's estimate is 3.8-fold (0.57 log units) below it; measured number inside the range.
By their numbers in this assay, from the lowest: compounds 2 and 1 (each within the scatter of the next); then compound 4; then compound 3.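

In this assay the aryl group on the amine nitrogen in the ring now falls on three separate levels, and the 3-nitrophenyl takes the middle one: a 3.4-fold lower number from compound 3 to compound 4 (0.53 log units; beyond the scatter) recovers only part of the loss seen with the 4-methoxy-2-methylphenyl, while an 8.8-fold higher number from compound 1 to compound 4 (0.95 log units; beyond the scatter) and a 17-fold higher number from compound 2 to compound 4 (1.23 log units; beyond the scatter) leave compound 4 clearly short of the other two. Removing the 4-methoxy-2-methylphenyl is therefore not enough on its own to return to the low numbers of compound 1 and compound 2, and the identity of the incoming aryl group counts at this position. Nothing available explains this order of the aryl groups.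

Open, from the compounds shown here alone, is whether the nitro group itself sets the level of compound 4, which a plain phenyl, or a nitrile or an amine in place of the nitro group on the same phenyl ring, would test. Also open, going by these compounds, is whether the same order of aryl groups holds with a longer chain joining this ring to the shared core.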